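The source may hold more compounds than are shown below. What is called first, only, known or untested is meant among the compounds shown, and "the series" means these compounds.

Measured so far:

Compound 1 `CN1CCN(c2ccc(-c3cc4[nH]nc(N)c4c(=O)[nH]3)cc2)CC1`: 35%
Compound 2 `Nc1n[nH]c2cc(CC3CCNCC3)[nH]c(=O)c12`: -56%
Compound 3 `Cc1cc2nn(-c3ccccc3)c(N)c2c(=O)[nH]1`: -49%

These three compounds were tested in an assay on isolated protein for inhibition of protein kinase C zeta type (Homo sapiens), read by mobility shift assay, tested at 30 uM; a lower number here means less inhibition, a higher number more inhibition at the concentration tested (going by the name of the read-out). Compound 3 stands second highest of the three numbers, but its nearest neighbour, compound 2, lies within the usual scatter of it, so the two cannot be told apart; only compound 1 stands clearly apart, beyond the scatter.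

Compound 4 `CC(C)(C)c1cc2nn(-c3ccccc3)c(N)c2c(=O)[nH]1` has not been measured yet. It differs from compound 3 in one place: tert-butyl in place of methyl on an aromatic carbon. Among the measured compounds shown here, no pair of measured compounds shows what such a change does here, so the step from compound 3 to compound 4 cannot be read from any measured pair. The expectation is a step of no size beyond the scatter, a number 9 percentage points higher from compound 3 to compound 4 (within the scatter). Compound 4 is therefore estimated at -40%, with a likely range from -75% to 0%.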

Compound 4, a percentage reported as inhibition, at one concentration (the size of the read-out at that concentration, not a potency): -1%
Compound 4: the middle estimate sits 39 percentage points below what was measured; low and high end bracket the measured number.
By their numbers in this assay, from the lowest: compounds 2 and 3 (each within the scatter of the next); then compound 4; then compound 1.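

On this aromatic carbon, next to the ring nitrogen, the group clearly matters: tert-butyl in place of methyl gives a number 48 percentage points higher from compound 3 to compound 4 (beyond the scatter), the first step read at this position. Even so, compound 4 remains well short of the top number in the set. Nothing measured here bears on the reason for this step.

Ethyl and isopropyl would show whether the number climbs gradually between methyl and tert-butyl. An amine or a carboxylic acid at this carbon would show whether a purely carbon group is needed at all.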